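This account rests on a few compounds, and the source may have more. Where it says the series, first, only, none or still open, it means among the compounds named here.

Measured so far in a functional assay on SMMC-7721 cells (Homo sapiens) for cytotoxicity, read by MTT assay, with a stated time of 24 h; a higher number here means a weaker inhibitor, a lower number a stronger inhibitor
Compound 1 (`CC(=O)Nc1ccc(S(=O)(=O)N2C/C(=C\c3ccncc3)C(=O)/C(=C/c3ccccc3F)C2)cc1`) gives 13400 nM
Compound 2 (`N#Cc1ccc(S(=O)(=O)N2C/C(=C\c3ccncc3)C(=O)/C(=C/c3ccccc3C(F)(F)F)C2)cc1`) gives 9610 nM

Compound 2 and compound 1 lie within the scatter of each other, so compound 2 does not stand apart on these numbers. Compound 3 (`CC(=O)Nc1ccc(S(=O)(=O)N2C/C(=C\c3ccncc3)C(=O)/C(=C/c3ccccc3C(F)(F)F)C2)cc1`) has acetamido in place of cyano on an aromatic carbon, para to a large group (acetamido in place of cyano on an aromatic carbon). For the measured compounds named here, no measured pair differs in one place, so the data give no size for such a step. No step beyond the scatter is expected in this assay. The estimated step (a 1.1-fold higher number from compound 2 to compound 3 (0.06 log units; within the scatter)) stays within the scatter. For compound 3 the estimated value is 11000 nM (expected range 5000 nM to 24000 nM).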

Compound 3, half-maximal inhibitory concentration: 5760 nM
For compound 3 the middle estimate is 1.9-fold (0.28 log units) above the measured one; low and high end bracket the measured number.
By their numbers in this assay, from the lowest: compounds 3, 2 and 1 (each within the scatter of the next, the first and the last beyond it).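

In this assay the exchange of cyano for acetamido on an aromatic carbon, para to a large group, gives a 1.7-fold lower number from compound 2 to compound 3 (0.22 log units; within the scatter) and so does not separate the two groups at this place. For the compounds shown here, with acetamido held, trifluoromethyl in place of fluoro on an aromatic carbon gives a 2.3-fold lower number from compound 1 to compound 3 (0.37 log units; beyond the scatter) as the only step here beyond the scatter. No measured evidence accounts for either step.

As far as these compounds go, whether an amine or a carboxylic acid at the cyano place would give a step beyond the scatter remains open. Also open, from the compounds shown here alone, is whether the trifluoromethyl step holds with cyano in place of acetamido.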